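From Bromo to 1-Methylethenyl on Compound 1

The compounds below may be only part of what the source reports. "The series", "measured", "known", "first", "only" and "open" are said of these compounds alone.

Compound 1 `CN1CCCN(CCn2ccc3ccc(Br)cc32)CC1` gives 93% in an assay on HEK293 cells for binding affinity to 5-hydroxytryptamine receptor 7 (Homo sapiens), read by radioligand binding, tested at 1 uM (on this read-out lower numbers stand for less inhibition and higher numbers for more inhibition at the one concentration tested (going by the name of the read-out)), the higher of the two numbers recorded so far. Compound 2 `Brc1ccc2ccn(CCN3CCN(C4CCCCC4)CC3)c2c1` gives 36% in this assay, a value far below that of compound 1 and well beyond the usual scatter of such measurements. Compound 3 `C=C(C)c1ccc2ccn(CCN3CCCN(C)CC3)c2c1` has not yet been measured. It differs from compound 1 in a single place: 1-methylethenyl in place of bromo on an aromatic carbon. Among the compounds with values here, no pair of measured compounds shows the effect of this particular replacement, so the size of the step cannot be read from the data. The author expects compound 3 to keep most of the inhibition seen in compound 1, with a step of a number 13 percentage points lower from compound 1 to compound 3 (beyond the scatter) expected to be small and downward, possibly within the scatter. Compound 3 is therefore estimated to give 80% in this assay, with a range from 55% to 95%.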

Compound 3, a percentage reported as inhibition, at one concentration (the size of the read-out at that concentration, not a potency): 72%
Compound 3: the middle estimate sits 8 percentage points above what was measured; the measured number falls inside the stated range.
By their numbers in this assay, from the lowest: compound 2; then compound 3; then compound 1.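

In this assay, replacing bromo with 1-methylethenyl on this aromatic carbon gives a number 21 percentage points lower from compound 1 to compound 3 (beyond the scatter), the first step recorded at this position. The step shows that bromo is not needed for substantial inhibition at the one concentration tested, since compound 3 still gives 72%, although the change costs inhibition beyond the usual scatter. The data available offer no explanation for the size of this step.

On these data alone, how an isopropyl or a methoxy group on this aromatic carbon would compare remains open, and with it whether the double bond of 1-methylethenyl has any part in the step. Also open, as far as these compounds go, is whether the same replacement would produce a similar step on compound 2, which carries a different amine ring.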